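A few compounds are considered here, and "the series" means these few. Any claim that something is new, unique, unknown or untested is made for them only; others in the source may bear on it.

Measured so far in a physicochemical assay for solubility, read by HPLC, in phosphate buffer, with a stated time of 4 h, at pH 7.4; a lower number here means a less soluble compound, a higher number a more soluble compound:
- compound 1 `COCCOC(=O)c1cc(N)c(Nc2ccc(C#N)cc2)cc1Oc1c(C)cc(/C=C/C#N)cc1C` gives 0.77 ug/mL
- compound 2 `Cc1cc(/C=C/C#N)cc(C)c1Oc1cc(Nc2ccc(C#N)cc2)c(N)cc1C(=O)NCCC(F)F` gives 6.59 ug/mL

Compound 1 holds the lowest of the two numbers in this assay; its nearest neighbour is compound 2, and the step between them, an 8.6-fold higher number from compound 1 to compound 2 (0.93 log units; beyond the scatter), is beyond the scatter. For the measured compounds named here, that step replaces the group on the carbonyl carbon of the shared core and is the only comparison available here.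

Compound 3 `Cc1cc(/C=C/C#N)cc(C)c1Oc1cc(Nc2ccc(C#N)cc2)c(N)cc1C(=O)N1CC1` is not yet measured in this assay. It differs from compound 1 in one place: aziridin-1-yl in place of 2-methoxyethoxy on a carbonyl carbon. The change sits at the same carbonyl carbon as the change from compound 1 to compound 2, so that measured step is the one that bears on it. Going by the values given here, no measured pair shows an aziridin-1-yl group, so its size can only be bracketed loosely.

Compound 3 is expected to show a rise of a 2.6-fold higher number from compound 1 to compound 3 (0.41 log units; beyond the scatter). Among the compounds with values here, that expected rise is meant to stay short of the one measured step in this assay. The estimate for compound 3 in this assay is 2 ug/mL, within a range of 0.6 ug/mL to 6.5 ug/mL.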

Compound 3, solubility: 1.2 ug/mL
For compound 3 the middle estimate is 1.7-fold (0.22 log units) above the measured one, and the stated range covers the measured number.
By their numbers in this assay, from the lowest: compounds 1 and 3 (each within the scatter of the next); then compound 2.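

In this assay, a 1.6-fold higher number from compound 1 to compound 3 (0.19 log units; within the scatter), so exchanging 2-methoxyethoxy for aziridin-1-yl on this carbonyl carbon gives no separation between the two compounds, and a change at this place does not by itself move the number. Compounds 2 and 3 both carry a nitrogen on the carbonyl carbon, yet a 5.5-fold lower number from compound 2 to compound 3 (0.74 log units; beyond the scatter), so among the three compounds the higher number goes with (3,3-difluoropropyl)amino specifically and not with nitrogen in that place in general, with compound 3 going against the broader reading. No measurement on hand gives a reason for this difference between the two nitrogen-linked groups.

The compounds shown leave open which feature of (3,3-difluoropropyl)amino goes with the higher number: the amide hydrogen, the fluorines or the length of the chain. A propylamino group without fluorine and a dimethylamino group on the same carbonyl carbon would bear on that question, the first by keeping the chain and the amide hydrogen, the second by keeping neither.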